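Phenethyl for butylsulfanyl on the thioether side chain

A few compounds are considered here, and "the series" means these few. Any claim that something is new, unique, unknown or untested is made for them only; others in the source may bear on it.

Working notes on the series. In a functional assay on a cell-free system (plasma) for inhibition of thromboxane A2 receptor (Homo sapiens) (on this read-out higher numbers stand for weaker inhibition and lower numbers for stronger inhibition), compound 2 `CCCCSCSCC1C2CCC(O2)C1C/C=C\CCCC(=O)O` gives 700 nM, the lowest of the two single numbers in hand; the nearest is compound 1 `CCCCCCSC[C@H]1C2CCC(O2)[C@H]1C/C=C\CCCC(=O)O`, which gives 3800 nM, a gap beyond the scatter. Compound 3 `CCCCCCCSC1C2CCC(O2)C1C/C=C\CCCC(=O)O` carries no single number; in this assay compound 3 gives 230000 nM; 35000 nM (2 entries), the entries the several entries of compound 3 in this assay, 230000 nM; 35000 nM (2 entries) spreading widely among themselves.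

The step to compound 4 `O=C(O)CCC/C=C\CC1C2CCC(O2)C1CSCCCc1ccccc1` is phenethyl in place of butylsulfanyl on a saturated chain carbon bound to a sulfur. For the measured compounds named here, no measured pair in the set isolates this change, and the variation across compound 1 and compound 2 concerns the chain on the sulfur rather than an aromatic end group.

The expectation for compound 4 is a step of a 1.4-fold lower number from compound 2 to compound 4 (0.15 log units; within the scatter), toward a somewhat lower number but not clearly beyond the scatter. In this assay compound 4 is estimated at 500 nM, with a range from 100 nM to 3000 nM.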

Compound 4, half-maximal inhibitory concentration: 5000 nM
Compound 4: the middle estimate sits 10-fold (1.00 log units) below what was measured; measured number above the stated range.
By their numbers in this assay, from the lowest: compound 2; then compounds 1 and 4 (each within the scatter of the next).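

Phenethyl in place of butylsulfanyl on a saturated chain carbon bound to a sulfur weakens inhibition, with a 7.1-fold higher number from compound 2 to compound 4 (0.85 log units; beyond the scatter) in this assay, so this place in the side chain does not accept the aromatic end group without loss. The change does two things at once: the sulfur of butylsulfanyl leaves, and one six-membered aromatic ring of carbon only enters, so the step cannot be assigned to either alone. Nothing in hand bears on the cause of this step.

As far as these compounds go, whether the loss follows the ring or the missing sulfur stays open. A cyclohexylethyl group in place of phenethyl, or a benzylsulfanyl group in place of butylsulfanyl, would separate the two.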